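This account rests on a few compounds, and the source may have more. Where it says the series, first, only, none or still open, it means among the compounds named here.

Compounds measured in a toxicity assay on NIH3T3 cells (Mus musculus) for cytotoxicity, read by resazurin assay; a higher number here means that more compound is needed for the effect, a lower number that less compound is needed:
Compound 1 `Cc1cccc(-c2cccc(NCc3cncn3Cc3ccccc3)c2)c1` gives the limit > 1000 nM.
Compound 3 `c1ccc(Cn2cncc2CNc2cccc(-c3cccnc3)c2)cc1` gives the limit > 1000 nM.
Compound 2 `COC(=O)c1ccc(NCc2cncn2Cc2ccc(C(C)(C)C)cc2)cc1-c1ccccc1` gives "not determined" (no result reported).

Compound 2 therefore stands nowhere on the numbers: no single value is known for it in this assay, and the two values shown for the other compounds are limits rather than numbers. The step that the two limits leave unreadable from compound 1 to compound 3 is not readable either, since both ends are limits.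

Compound 4 `COC(=O)c1ccc(NCc2cncn2Cc2ccc([N+](=O)[O-])cc2)cc1-c1ccccc1` has not yet been measured. It differs from compound 2 by nitro in place of tert-butyl on an aromatic carbon. Within the data shown here, no measured step bears directly on this change. What the data offer is the limit of > 1000 nM in this assay, at which 2 of the 3 values shown sit, which suggests that compounds of this shared core tend not to reach a measurable effect in this assay. On that ground alone, compound 4 is expected to behave like compounds 1 and 3, most likely giving only a limit. The estimate for compound 4 is 3000 nM, with a range from 800 nM to 20000 nM.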

Compound 4, half-maximal effective concentration: > 10000 nM
Compound 4: no number, only a limit; the forecaster's own chance of this, stated with the estimate: 75%; middle value at least 3.3-fold (0.52 log units) from the limit.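

In this assay compound 4 gives > 10000 nM, which is a limit and not a number. No step can be read between compound 2 and compound 4, since compound 2 has no result. The compounds shown leave open what concentration any of them needs for an effect in this assay.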